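Swapping the aryl halogens on a shared core

The source may report more compounds than this note shows. Statements on the series, on what has been measured and on what is new or still open speak of the compounds shown alone.

Of the compounds shown here, three built on one shared core have been tested in an assay on HEK-293T cells for displacement of a labelled ligand from corticotropin-releasing factor receptor 1 (Homo sapiens), read by scintillation counting, with a stated time of 2 h; on this read-out lower numbers stand for stronger inhibition and higher numbers for weaker inhibition. Compound 1, `CCCCN(CC)c1cc(C)nc2c1NC(=O)CN2c1ccc(C)cc1Cl`, gives 4.4 nM. Compound 2, `CCCCN(CC)c1cc(C)nc2c1NC(=O)CN2c1ccc(C(C)(C)C)cc1Br`, gives 4.2 nM. Compound 3, `CCCCN(CC)c1cc(C)nc2c1NC(=O)CN2c1ccc(Br)cc1Cl`, gives 2.7 nM. On these numbers compound 1 has the highest value, yet its gap to compound 2 and its gap to compound 3 both lie within the scatter, so no order among the three can be claimed.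

The unmeasured compound 4, `CCCCN(CC)c1cc(C)nc2c1NC(=O)CN2c1ccc(Br)cc1Br`, differs from compound 1 in one place: 2,4-dibromophenyl in place of 2-chloro-4-methylphenyl on a nitrogen on an aromatic ring in a ring. Part of this change has a measured counterpart, the step of a 1.6-fold lower number from compound 1 to compound 3 (0.21 log units; within the scatter), which exchanges methyl for bromo on the aromatic carbon and stays within the scatter. The other part, bromo in place of chloro on the same aryl group, has no direct comparison; compound 2 carries bromo there with a different second group and shows a value close to that of compound 1. Compound 4 is therefore expected to change by a 1.5-fold lower number from compound 1 to compound 4 (0.17 log units; within the scatter), a step within the scatter. The estimate for compound 4 in this assay is 3 nM, with a range from 1.2 nM to 8 nM.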

Compound 4, inhibition constant: 1.3 nM
Estimate against measurement, compound 4: 2.3-fold (0.36 log units) above; the measured number falls inside the stated range.
By their numbers in this assay, from the lowest: compound 4; then compounds 3, 2 and 1 (each within the scatter of the next).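

Bromo in place of chloro on the aromatic carbon gives the first step among these compounds that lies beyond the scatter (a 2.1-fold lower number from compound 3 to compound 4 (0.32 log units; beyond the scatter)), so the read-out does respond to a change at this position of the aryl group. The whole exchange to 2,4-dibromophenyl also clears the scatter (a 3.4-fold lower number from compound 1 to compound 4 (0.53 log units; beyond the scatter)), as does bromo in place of tert-butyl (a 3.2-fold lower number from compound 2 to compound 4 (0.51 log units; beyond the scatter)). Within the data shown here, all three steps are modest, yet together they set compound 4 apart as the strongest of the four, whereas the earlier compounds could not be ranked.

The compounds shown leave open whether iodo or methoxy in place of bromo on the aromatic carbon would lower the number further or raise it. Nothing measured here bears on the reason for these differences.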